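Ester enlargement on the shared core with a free sugar

This account rests on a few compounds, and the source may have more. Where it says the series, first, only, none or still open, it means among the compounds named here.

Compound 1 `C/C=C1/[C@H](O[C@@H]2O[C@H](CO)[C@@H](O)[C@H](O)[C@H]2O)OC=C(C(=O)OC)[C@H]1CC(=O)NCCC` carries a propylamino amide on the shared core with the unprotected sugar. In a functional assay on SK-BR-3 cells (Homo sapiens) for antiproliferative activity, read by MTT assay, with a stated time of 72 h (a lower number here means a stronger inhibitor, a higher number a weaker inhibitor), compound 1 gives > 20000 nM, which is a limit of the assay rather than a number. Compound 2 `C/C=C1/[C@H](O[C@@H]2O[C@H](COC(C)=O)[C@@H](OC(C)=O)[C@H](OC(C)=O)[C@H]2OC(C)=O)OC=C(C(=O)OC)[C@H]1CC(=O)OC` bears the acetylated sugar and a methyl ester; in this assay compound 2 gives > 15000 nM, again only a limit. Compound 3 `C/C=C1/[C@H](O[C@@H]2O[C@H](COC(C)=O)[C@@H](OC(C)=O)[C@H](OC(C)=O)[C@H]2OC(C)=O)OC=C(C(=O)OC)[C@H]1CC(=O)OCCC` with the propyl ester gives 6600 nM in this assay, and the step of an at least 2.2-fold lower number from compound 2 to compound 3 (0.35 log units; beyond the scatter) shows that the larger ester lowers the number. Compound 4 `C/C=C1/[C@H](O[C@@H]2O[C@H](CO)[C@@H](O)[C@H](O)[C@H]2O)OC=C(C(=O)OC)[C@H]1CC(=O)OCCc1ccc([N+](=O)[O-])cc1` differs from compound 1 by a group of 12 heavy atoms (8 carbon, 1 nitrogen, 3 oxygen; one six-membered aromatic ring of carbon only) in place of a group of 4 heavy atoms (3 carbon, 1 nitrogen; no ring), on a carbonyl carbon. Among the compounds with values here, no measured step covers an amide-to-ester change, and compound 1 sits at a limit, so only the direction of an at least 2.2-fold lower number from compound 2 to compound 3 (0.35 log units; beyond the scatter) offers guidance. Compound 4 is therefore expected near 15000 nM in this assay, between 4000 nM and 60000 nM, a step of an at least 1.3-fold lower number from compound 1 to compound 4 (0.12 log units; that floor lies within the scatter) that remains a rough expectation.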

Compound 4, half-maximal inhibitory concentration: > 20000 nM
Compound 4 ended at the assay's limit; the forecaster's own chance of this, stated with the estimate: 45%; middle value at least 1.3-fold (0.12 log units) from the limit.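

Compound 1 and compound 4 both sit at an assay limit, so the step between them cannot be read. As far as these compounds go, whether replacing propylamino changes the number on the shared core with the free sugar remains open.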